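This account rests on a few compounds, and the source may have more. Where it says the series, first, only, none or still open, it means among the compounds named here.

Working notes on the series. Compound 1 `OC[C@H]1O[C@@H](n2cc(F)c3c(-c4ccco4)ncnc32)[C@H](O)[C@@H]1O` and compound 2 `OC[C@H]1O[C@@H](n2cc(F)c3c(-c4ccoc4)ncnc32)[C@H](O)[C@@H]1O` share one core and differ only in the change (furan-3-yl in place of furan-2-yl on an aromatic carbon). In an ADME assay on BJ cells (Homo sapiens) for cytotoxicity, read by MTT assay, with a stated time of 72 h (a higher number here means that more compound is tolerated, a lower number that less compound is tolerated), compound 1 gives 310 nM. In this assay compound 2 gives 350 nM. The step of a 1.1-fold higher number from compound 1 to compound 2 (0.05 log units; within the scatter) is therefore small. Compound 3 `CCCCCCCCCCCCCCCCCCOP(=O)(O)OC[C@H]1O[C@@H](n2ccc3c(-c4ccco4)ncnc32)[C@H](O)[C@@H]1O` carries a different core; how its core differs from that of compound 1 is not broken down here. In this assay compound 3 reaches only a limit of the assay, > 50000 nM. That is the limit (the limit of > 50000 nM in this assay, at which 1 of the 3 values shown sits). Compound 4 `CCCCCCCCCCCCCCCCCCOP(=O)(O)OC[C@H]1O[C@@H](n2ccc3c(-c4ccoc4)ncnc32)[C@H](O)[C@@H]1O` stands to compound 3 as compound 2 stands to compound 1, through the same change (furan-3-yl in place of furan-2-yl on an aromatic carbon), with the place described in identical words. The expected step of a number no higher from compound 3 to compound 4 (the limit leaves the size open) is taken to be about as small as the measured step of a 1.1-fold higher number from compound 1 to compound 2 (0.05 log units; within the scatter). Compound 4 is thus estimated to give 50000 nM, with a range from 25000 nM to 100000 nM.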

Compound 4, half-maximal cytotoxic concentration: 44200 nM
For compound 4 the middle estimate is 1.1-fold (0.05 log units) above the measured one, and the stated range covers the measured number.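

In this assay the change from furan-2-yl to furan-3-yl gives an at least 1.1-fold lower number from compound 3 to compound 4 (0.05 log units; that floor lies within the scatter), and this step is only a floor, since the value of compound 3 is a limit of the assay. Set beside the step on the other core, it gives no sign that the change acts differently on the two cores, but it does not show that the two steps match either: the same change on two cores in this assay, a 1.1-fold higher number (0.05 log units; within the scatter) from compound 1 to compound 2 and an at least 1.1-fold lower number (0.05 log units; that floor lies within the scatter) from compound 3 to compound 4; the limit leaves it open whether they differ. Two cores, one of them with a limit in place of a number, do not establish that the change carries across this series.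

As far as these compounds go, the true size of the step on the core of compound 3 stays open. Also open, from the compounds shown here alone, is what an amine or a phenyl group on the same aromatic carbon would give in this assay.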